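Cytotoxicity notes: nitro in place of phenyl

The source may hold more compounds than are shown below. What is called first, only, known or untested is meant among the compounds shown, and "the series" means these compounds.

Compound 3 `COC(=O)c1ccc(NCc2cncn2Cc2ccc(-c3ccccc3)cc2)cc1-c1ccccc1` is known in a toxicity assay on NIH3T3 cells (Mus musculus) for cytotoxicity, read by resazurin assay (a higher number here means that more compound is needed for the effect, a lower number that less compound is needed), only as a limit, > 1000 nM. Compound 1 `COC(=O)c1ccc(NCc2cncn2Cc2ccc(C#N)cc2)cc1-c1ccccc1` likewise gives only a limit there, > 10000 nM. For compound 2 `COC(=O)c1ccc(NCc2cncn2Cc2ccc(OC)cc2)cc1-c1ccccc1` this assay reports "not determined" (no result reported). For the measured compounds named here, the one measured step, a step that the two limits leave unreadable from compound 1 to compound 3, cannot be sized, as both of its ends are limits (the limit of > 1000 nM in this assay, at which 1 of the 3 values shown sits, and (the limit of > 10000 nM in this assay, at which 1 of the 3 values shown sits)). Compound 4 `COC(=O)c1ccc(NCc2cncn2Cc2ccc([N+](=O)[O-])cc2)cc1-c1ccccc1` carries the change (nitro in place of phenyl on an aromatic carbon). No readable measured step bears on this change, so the working assumption is a step within the usual scatter, with the value again lying at or beyond a limit of this assay. Compound 4 is therefore expected to give 20000 nM in this assay, within 5000 nM to 100000 nM, most likely reported only as a limit. The expected step that the limit leaves unreadable from compound 3 to compound 4 reflects that assumption.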

Compound 4, half-maximal effective concentration: > 10000 nM
Compound 4 was reported as a limit; the forecaster's own chance of this, stated with the estimate: 80%; the middle value does not contradict the limit.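

In this assay, for the compounds shown here, compound 3 and compound 4 are both reported only as limits, as is compound 1, and no step among them can be read. The compounds shown leave open whether nitro in place of phenyl shifts cytotoxicity at all.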